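Aryl swap on the triazole nitrogen: compound 3 to compound 4

The source may hold more compounds than are shown below. What is called first, only, known or untested is meant among the compounds shown, and "the series" means these compounds.

Measured compounds:
compound 1 `Cc1ccccc1-n1nncc1CN1C(=O)C2(C(C#N)=C(N)Oc3c2c2nc4ccccc4nc2c2ccccc32)c2ccccc21`; in a functional assay on A549 cells (Homo sapiens) for antiproliferative activity, read by MTT assay, with a stated time of 48 h (a higher number here means a weaker inhibitor, a lower number a stronger inhibitor), compound 1 gives > 50000 nM, a limit of the assay.
compound 2 `Cc1ccccc1-n1nncc1CN1C(=O)C2(C(C#N)=C(N)Oc3c(N)cc4nc5ccccc5nc4c32)c2ccccc21`; in this assay compound 2 gives 31700 nM.
compound 3 `N#CC1=C(N)Oc2c(N)cc3nc4ccccc4nc3c2C12C(=O)N(Cc1cnnn1-c1ccc(F)cc1)c1ccccc12`; in this assay compound 3 gives > 50000 nM, again a limit.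

Compound 3 therefore stands only as a limit, not as a number, and compound 1 sits at the same limit, as the limit of > 50000 nM in this assay, at which 2 of the 3 values shown sit, records. Going by the values given here, compound 2 is the only member with a measured number. The step of an at least 1.5-fold higher number from compound 2 to compound 3 (0.19 log units; that floor lies within the scatter) is itself only a floor, and that floor lies within the scatter.

Compound 4 `N#CC1=C(N)Oc2c(N)cc3nc4ccccc4nc3c2C12C(=O)N(Cc1cnnn1-c1cccc(Br)c1)c1ccccc12` is not yet measured. It differs from compound 3 by 3-bromophenyl in place of 4-fluorophenyl on an aromatic nitrogen. Among the compounds with values here, the one measured step that bears on this kind of change is an at least 1.5-fold higher number from compound 2 to compound 3 (0.19 log units; that floor lies within the scatter), an exchange of the aryl group on the same aromatic nitrogen, which produced no change that can be called larger than the scatter. On that basis no step beyond the scatter is expected in this assay from compound 3 to compound 4, and the most likely outcome is that compound 4 again reports only a limit.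

The expected step is a step that the limit leaves unreadable from compound 3 to compound 4. For compound 4 the estimate in this assay is 60000 nM, in the range 25000 nM to 150000 nM.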

Compound 4, half-maximal inhibitory concentration: 18900 nM
Compound 4: the middle estimate sits 3.2-fold (0.50 log units) above what was measured, outside the stated range (below it).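

The exchange of 4-fluorophenyl for 3-bromophenyl on this aromatic nitrogen reads in this assay as an at least 2.6-fold lower number from compound 3 to compound 4 (0.42 log units; beyond the scatter), so the aryl group here can carry a change beyond the scatter, which the earlier floor of an at least 1.5-fold higher number from compound 2 to compound 3 (0.19 log units; that floor lies within the scatter) could not show. The comparison of 2-methylphenyl with 3-bromophenyl reads as a 1.7-fold lower number from compound 2 to compound 4 (0.22 log units; within the scatter), so these two aryl groups cannot be ranked, and the separation seen so far concerns 4-fluorophenyl alone. Compound 3 stands only at a limit, so the step from it gives a floor and not a size: the limit of > 50000 nM in this assay, at which 2 of the 4 values shown sit.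

The halogen and its place on the phenyl ring change together in this step, and 3-fluorophenyl and 4-bromophenyl on the same nitrogen would be needed to tell the two apart. Also open, as far as these compounds go, is how far this position tolerates other substituents, such as an amine or a carboxylic acid on the phenyl ring, or a benzyl group in place of the aryl group.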